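Replacing 1H-pyrazol-4-yl with 1H-imidazol-1-yl

A few compounds are considered here, and "the series" means these few. Any claim that something is new, unique, unknown or untested is made for them only; others in the source may bear on it.

Measured in a functional assay on MCF7 cells (Homo sapiens) for antiproliferative activity, read by CellTiter-Glo, with a stated time of 5 days; a lower number here means a stronger inhibitor, a higher number a weaker inhibitor:
- compound 1 `CC/C(=C(/c1ccc(/C=C/C(=O)O)cc1)c1ccc(-c2cnsc2)cc1)c1ccccc1`: 120 nM
- compound 2 `CC/C(=C(/c1ccc(/C=C/C(=O)O)cc1)c1ccc(-c2cc[nH]n2)cc1)c1ccccc1`: 440 nM
- compound 3 `CC/C(=C(/c1ccc(/C=C/C(=O)O)cc1)c1ccc(-c2cn[nH]c2)cc1)c1ccccc1`: 40 nM

Compound 3, at 40 nM, has the lowest number of the three and is the strongest inhibitor here, since its steps to both others lie beyond the scatter. Compound 4 `CC/C(=C(/c1ccc(/C=C/C(=O)O)cc1)c1ccc(-n2ccnc2)cc1)c1ccccc1` keeps the shared core and changes only the five-membered ring: 1H-imidazol-1-yl in place of 1H-pyrazol-4-yl on an aromatic carbon. This puts 1H-imidazol-1-yl in place of 1H-pyrazol-4-yl on an aromatic carbon, para to a large group.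

Among the measured compounds shown here, no measured compound carries this new group, so the closest evidence comes from other ring swaps at the same place. For the measured compounds named here, two steps bear on it: a 3.0-fold lower number from compound 1 to compound 3 (0.48 log units; beyond the scatter), which is modest, and an 11-fold lower number from compound 2 to compound 3 (1.04 log units; beyond the scatter), which is large. The second shows that rearranging the same ring atoms can matter a great deal. Both other rings give higher numbers than compound 3, so a modest rise is expected in this assay, though a large one remains possible. The expected step is a 3.3-fold higher number from compound 3 to compound 4 (0.51 log units; beyond the scatter). For compound 4 the estimated value is 130 nM, with an expected range of 40 nM to 450 nM.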

Compound 4, half-maximal inhibitory concentration: 380 nM
Compound 4: the middle estimate sits 2.9-fold (0.47 log units) below what was measured; the measured number falls inside the stated range.
By their numbers in this assay, from the lowest: compound 3; then compound 1; then compounds 4 and 2 (each within the scatter of the next).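

Among the compounds shown here, compound 4 shows that the arrangement of atoms in this five-membered ring matters even more than the earlier compounds suggested: 1H-imidazol-1-yl in place of 1H-pyrazol-4-yl gives a 9.5-fold higher number from compound 3 to compound 4 (0.98 log units; beyond the scatter) in this assay, although the two groups have the same heavy atoms and the count of hydrogen-bond donors falls from 1 to 0. The step between the two weaker rings is a 1.2-fold lower number from compound 2 to compound 4 (0.06 log units; within the scatter), so 1H-imidazol-1-yl and 1H-pyrazol-3-yl cannot be told apart here, which leaves compound 3 alone among the three rings built from these atoms. The sulfur-containing ring also stays ahead of the new one, with a 3.2-fold higher number from compound 1 to compound 4 (0.50 log units; beyond the scatter).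

No measurement shown explains why these rings differ. From the compounds shown here alone, whether a triazole ring or a methyl group on the pyrazole nitrogen would keep the low number of compound 3 remains open.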